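This account rests on a few compounds, and the source may have more. Where it says the series, first, only, none or still open, it means among the compounds named here.

Compound 1, `Cc1ncsc1-c1ccc(CNC(=O)[C@@H]2C[C@@H](O)CN2C(=O)[C@@H](NC(=O)COCCOCCn2cc(CCOc3ccc(Cl)cc3C(=O)Nc3ccc([N+](=O)[O-])cc3Cl)nn2)C(C)(C)C)cc1`, in a functional assay on LNCaP cells (Homo sapiens) for inhibition, read by WST assay, with a stated time of 3 days; a higher number here means a weaker inhibitor, a lower number a stronger inhibitor: 1040 nM
Compound 2, `C#CCCOc1ccc(Cl)cc1C(=O)Nc1ccc([N+](=O)[O-])cc1Cl`: > 10000 nM
Compound 3, `CC(C)(C)OC(=O)COCCOCCn1cc(CCOc2ccc(Cl)cc2C(=O)Nc2ccc([N+](=O)[O-])cc2Cl)nn1`: 3080 nM

The measured compounds share a core and differ in the chain attached to it. For compound 2 the result in this assay is a limit of the assay rather than a number, so it only shows that no inhibition was reached within the tested range (the limit of > 10000 nM in this assay, at which 1 of the 3 values shown sits). Of the two compounds with a number, compound 3 stands highest, which here means the weaker of the two inhibitors. Its nearest neighbour is compound 1, whose number is lower by a gap that lies beyond the usual scatter of repeated measurements.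

The next compound, compound 4, `O=C(O)COCCOCCn1cc(CCOc2ccc(Cl)cc2C(=O)Nc2ccc([N+](=O)[O-])cc2Cl)nn1`, has not yet been measured. It comes from compound 3 by a single change: hydrogen in place of tert-butyl on an oxygen next to a carbonyl group. Within the data shown here, no measured pair shows this same change, so there is no directly comparable step. The step from compound 3 to compound 4 is expected to be modest and toward a higher number, a 1.6-fold higher number from compound 3 to compound 4 (0.21 log units; within the scatter), with a real chance that only a limit is reported. Compound 4 is therefore estimated at 5000 nM, within a range from 1500 nM to 15000 nM.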

Compound 4, half-maximal inhibitory concentration: > 10000 nM
Compound 4: no number, only a limit (the forecaster's own chance of this, stated with the estimate: 35%); middle value at least 2.0-fold (0.30 log units) from the limit.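

In this assay, compound 4 gives > 10000 nM, which is a limit of the assay and not a number. Even so, the change can be read in one direction: swapping tert-butyl for hydrogen on an oxygen next to a carbonyl group, which turns the tert-butoxycarbonyl end of the chain into a carboxy end, gives an at least 3.2-fold higher number from compound 3 to compound 4 (0.51 log units; beyond the scatter), so the inhibitor is weaker by a margin beyond the usual scatter, though the full size of the step stays unknown. The earlier compounds differed in more than one place, so this is the first direct view of what this end of the chain does while everything else stays fixed, and it places compound 4 at the same limit as compound 2: the limit of > 10000 nM in this assay, at which 2 of the 4 values shown sit.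

The compounds shown leave open how a methyl ester, an amide or an amine would read at this chain end, and so whether the drop follows from losing the tert-butyl or from gaining the carboxylic acid. They also leave open whether a longer chain carrying the carboxylic acid would bring a measurable number back into range.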